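From 2-fluorophenyl to 3-methoxyphenyl on an amine nitrogen

This account rests on a few compounds, and the source may have more. Where it says the series, first, only, none or still open, it means among the compounds named here.

In a functional assay on HT-29 cells (Homo sapiens) for cytotoxicity, read by sulforhodamine B assay (a higher number here means a weaker inhibitor, a lower number a stronger inhibitor), compound 3 `C=C1[C@@H](OC(C)=O)C[C@@H]2[C@](C)(CO[Si](C)(C)C(C)(C)C)[C@H](OC(C)=O)CC[C@@]2(C)[C@@H]1C[C@@H](Nc1ccccc1F)C1=CCOC1=O` gives 3710 nM. Compound 1 `C=C1CC[C@@H]2[C@](C)(CO[Si](C)(C)C(C)(C)C)[C@H](OC(C)=O)CC[C@@]2(C)[C@@H]1C/C=C1/C(=O)OC[C@H]1OC(C)=O` gives 4690 nM, which lies within the scatter of the value for compound 3. Compound 2 `C=C1[C@@H](OC(C)=O)C[C@@H]2[C@](C)(COC=O)[C@H](OC(C)=O)CC[C@@]2(C)[C@@H]1C[C@@H](Nc1ccccc1F)C1=CCOC1=O` gives 9760 nM, and the only measured step between two of these compounds that differ in one place is a 2.6-fold lower number from compound 2 to compound 3 (0.42 log units; beyond the scatter). That modest step exchanges a group on an oxygen on a saturated carbon, so it leaves the amine nitrogen untouched.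

Compound 4 `C=C1[C@@H](OC(C)=O)C[C@@H]2[C@](C)(CO[Si](C)(C)C(C)(C)C)[C@H](OC(C)=O)CC[C@@]2(C)[C@@H]1C[C@@H](Nc1cccc(OC)c1)C1=CCOC1=O` differs from compound 3 at that nitrogen: 3-methoxyphenyl in place of 2-fluorophenyl on an amine nitrogen. Within the data shown here, no measured step in this small set changes the group on the amine nitrogen, so the data offer no direct guide to the size or direction of this change. With nothing pointing either way, no step beyond the scatter is expected, and the estimated step is a 1.0-fold higher number from compound 3 to compound 4 (0.01 log units; within the scatter). For compound 4 the estimated value is 3800 nM, with an expected range from 1700 nM to 8500 nM.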

Compound 4, half-maximal inhibitory concentration: > 50000 nM
Compound 4: no number, only a limit; the forecaster's own chance of this, stated with the estimate: 5%; middle value at least 13-fold (1.11 log units) away from the limit.
By their numbers in this assay, from the lowest: compounds 3 and 1 (each within the scatter of the next); then compound 2. At a limit, above all of these: compound 4.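

The group on the amine nitrogen proves to matter a great deal in this assay: the change from 2-fluorophenyl to 3-methoxyphenyl gives an at least 13-fold higher number from compound 3 to compound 4 (1.12 log units; beyond the scatter). This large step at the nitrogen exceeds the modest one at the group on the oxygen, which was a 2.6-fold lower number from compound 2 to compound 3 (0.42 log units; beyond the scatter). For compound 4 the reading is a limit of the assay and not a number: the limit of > 50000 nM in this assay, at which 1 of the 4 values shown sits.

The 2-fluorophenyl and 3-methoxyphenyl groups differ both in the substituent and in its number on the ring, and with neither 3-fluorophenyl nor 2-methoxyphenyl among the compounds shown, it stays open which of the two differences counts. Also open, as far as these compounds go, is how an unsubstituted phenyl, or a simple alkyl chain, on this nitrogen would read in this assay.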